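Compound 4: replacing the 3,4-dichlorophenyl amide group

This account rests on a few compounds, and the source may have more. Where it says the series, first, only, none or still open, it means among the compounds named here.

Compound 2 (`COc1cc(/C=C/C(=O)Nc2ccccc2N)ccc1OCC(=O)Nc1ccc(Cl)c(Cl)c1`) gives 72100 nM in a functional assay on HeLa cells (Homo sapiens) for inhibition, read by MTT assay, with a stated time of 48 h (a higher number here means a weaker inhibitor, a lower number a stronger inhibitor), and holds the highest of the two numeric values in the series. Compound 1 (`COc1cc(/C=C/C(=O)Nc2ccccc2N)ccc1OCC(=O)Nc1cccc(F)c1`) gives 28100 nM in this assay as the other numeric value. Compound 3 (`COc1cc(/C=C/C(=O)NO)ccc1OCC(=O)Nc1ccc(Br)cc1`) reads > 100000 nM in this assay and this is a limit of the assay, not a number.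

Compound 4 (`COc1ccc(NC(=O)COc2ccc(/C=C/C(=O)Nc3ccccc3N)cc2OC)cc1`) has not been measured. The structural change is 4-methoxyphenyl in place of 3,4-dichlorophenyl on an amide-type nitrogen and it puts 4-methoxyphenyl in place of 3,4-dichlorophenyl on an amide-type nitrogen. Within the data shown here, only one measured step bears on this position: a 2.6-fold higher number from compound 1 to compound 2 (0.41 log units; beyond the scatter) with 3,4-dichlorophenyl in place of 3-fluorophenyl. Among the measured compounds shown here, no measured compound carries 4-methoxyphenyl, so this single step is a weak guide. Since 3,4-dichlorophenyl came with the higher number in that pair, its removal is expected to give a small move toward a lower number, no larger than the measured step. The estimated step is a 1.8-fold lower number from compound 2 to compound 4 (0.26 log units; within the scatter) in this assay on this reasoning. Compound 4 is expected at 40000 nM in this assay with an estimated range from 15000 nM to 95000 nM as the working figures.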

Compound 4, half-maximal inhibitory concentration: > 100000 nM
Compound 4: no number, only a limit; the forecaster's own chance of this, stated with the estimate: 12%; middle value at least 2.5-fold (0.39 log units) from the limit.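

At this position, on an amide-type nitrogen, the reading is an at least 1.3-fold higher number from compound 2 to compound 4 (0.14 log units; that floor lies within the scatter) and gives no sign of the lower number that the earlier fluoro-to-dichloro pair hinted at, although that floor alone does not establish a real rise. The comparison with the 3-fluorophenyl compound is firmer, at an at least 3.5-fold higher number from compound 1 to compound 4 (0.55 log units; beyond the scatter) for the same core, and among these three groups on this nitrogen, the 3-fluorophenyl of compound 1 keeps the lowest number, so the choice of aryl group clearly registers in this assay even at these high concentrations. Compound 4 gives only a limit, not a number, so neither step has an upper size: the limit of > 100000 nM in this assay, at which 2 of the 4 values shown sit.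

The compounds shown do not separate the effect of placing a substituent at the 4-position from that of the methoxy group itself, for which a 3-methoxyphenyl or an unsubstituted phenyl would be the direct comparison. Also open, on these data alone, is whether an amine, a carboxylic acid or a longer alkyl chain in place of the 4-methoxyphenyl group would bring the number under that of compound 1.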